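This account rests on a few compounds, and the source may have more. Where it says the series, first, only, none or still open, it means among the compounds named here.

Compound 1 `CCCn1c(=O)n(CCC#N)c(=O)c2[nH]cnc21` and compound 2 `CCCn1c(=O)n(CCN(C)C)c(=O)c2[nH]cnc21` share one core, and compound 3 `CCCn1c(=O)n(C)c(=O)c2c1ncn2CCC#N` and compound 4 `CCCn1c(=O)n(C)c(=O)c2c1ncn2CCN(C)C` share another; the difference between the two cores is not broken down here. In a functional assay (trachea) with Cavia porcellus as the target (on this read-out lower numbers stand for an effect already at smaller amounts and higher numbers for an effect only at larger amounts of compound), compound 1 gives 1700 nM, compound 2 gives 2700 nM and compound 3 gives 27600 nM. The change from compound 1 to compound 2, (dimethylamino in place of cyano on a saturated chain carbon, two bonds along the chain from an aromatic nitrogen), produced a 1.6-fold higher number from compound 1 to compound 2 (0.20 log units; within the scatter). Compound 4 is not yet measured in this assay. It arises from compound 3 by the same change, (dimethylamino in place of cyano on a saturated chain carbon, two bonds along the chain from an aromatic nitrogen), at the same place. Because the earlier step was a 1.6-fold higher number from compound 1 to compound 2 (0.20 log units; within the scatter), a step of similar small size is expected here, a 1.4-fold higher number from compound 3 to compound 4 (0.16 log units; within the scatter), though the cores differ and the scatter of this assay is wide. Compound 4 is therefore estimated at 40000 nM, with a likely range from 15000 nM to 100000 nM.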

Compound 4, half-maximal effective concentration: > 100000 nM
Compound 4 was reported as a limit; the forecaster's own chance of this, stated with the estimate: 10%; at least 2.5-fold (0.39 log units) between middle value and limit.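

In this assay compound 4 gives > 100000 nM, which is a limit of the assay and not a number. Going by these compounds, on this core, the swap of cyano for dimethylamino gives an at least 3.6-fold higher number from compound 3 to compound 4 (0.55 log units; beyond the scatter), so the step stands clear of the scatter even though its full size is unknown. Whether the change has the same size on both cores cannot be decided, so this pair neither proves nor rules out that it carries over unchanged: the same change on two cores in this assay, a 1.6-fold higher number (0.20 log units; within the scatter) from compound 1 to compound 2 and an at least 3.6-fold higher number (0.55 log units; beyond the scatter) from compound 3 to compound 4; the limit leaves it open whether they differ

The compounds shown leave open how other groups at this place would behave on either core, such as a carboxylic acid or a cyclic amine. They also leave open whether a longer chain carrying the dimethylamino group would give a step of similar size.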